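Sulfonyl Aryl Variation in a Cytotoxicity Series

The source may report more compounds than this note shows. Statements on the series, on what has been measured and on what is new or still open speak of the compounds shown alone.

Compound 1 `CCN(CC)CCNC(=O)Nc1nc2ccc(-c3cnc(OC)c(NS(=O)(=O)c4ccc(C)cc4)c3)cn2n1` gives 730 nM in a functional assay on A549 cells (Homo sapiens) for cytotoxicity, read by MTT assay, with a stated time of 72 h; on this read-out lower numbers stand for stronger inhibition and higher numbers for weaker inhibition.
Compound 2 `CCN(CC)CCNC(=O)Nc1nc2ccc(-c3cnc(OC)c(NS(=O)(=O)c4ccc(F)cc4F)c3)cn2n1` gives 980 nM in this assay.
Compound 3 `CCN(CC)CCNC(=O)Nc1nc2ccc(-c3cnc(OC)c(NS(=O)(=O)c4ccc(Cl)cc4)c3)cn2n1` awaits measurement in this assay.

For the measured compounds named here, compound 2 stands at the highest of the two numbers measured so far, though its nearest neighbour, compound 1, sits within the scatter of it. Going by the values given here, the only measured step bearing on the new compound is a 1.3-fold higher number from compound 1 to compound 2 (0.13 log units; within the scatter), which shows that exchanging the aryl group on the sulfonyl sulfur left the read-out essentially unchanged.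

Compound 3 carries the change (4-chlorophenyl in place of 2,4-difluorophenyl on a sulfonyl sulfur). Among the compounds with values here, since the one comparable step stayed within the scatter, no step beyond the scatter is expected here either, in either direction. Compound 3 is therefore estimated to give about 800 nM, with a range from 400 nM to 1600 nM. The expected step is a 1.2-fold lower number from compound 2 to compound 3 (0.09 log units; within the scatter).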

Compound 3, half-maximal inhibitory concentration: 680 nM
Beside the measured number, compound 3's estimate is 1.2-fold (0.07 log units) above it, and the stated range covers the measured number.
By their numbers in this assay, from the lowest: compounds 3, 1 and 2 (each within the scatter of the next).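

In this assay, the sulfonyl sulfur now carries three aryl groups that the read-out does not separate: 4-chlorophenyl in place of 2,4-difluorophenyl gives a 1.4-fold lower number from compound 2 to compound 3 (0.16 log units; within the scatter) and stays level with the earlier pair. For the compounds shown here, the new compound also supplies the first comparison at this position in which a single group on the ring is exchanged, since chloro in place of methyl on an aromatic carbon gives a 1.1-fold lower number from compound 1 to compound 3 (0.03 log units; within the scatter) and likewise does not move the result beyond the scatter. No measurement is at hand that would account for this flat picture.

From the compounds shown here alone, whether an amine or a carboxylic acid on the phenyl ring would move the number beyond the scatter remains open. The same holds for a longer alkyl chain on the sulfonyl sulfur in place of the aryl group.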